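From 3-fluorophenyl to 3,5-dimethoxyphenyl on the shared core

The source may report more compounds than this note shows. Statements on the series, on what has been measured and on what is new or still open speak of the compounds shown alone.

Going by the values given here, in an ADME assay on WI-38 cells (Homo sapiens) for cytotoxicity, read by MTT assay, with a stated time of 72 h (a higher number here means a weaker inhibitor, a lower number a stronger inhibitor), compound 1 `O=C(CCc1cccc2c1B(O)OC2)Nc1cccc(-c2ccccc2)c1` gives 12000 nM and compound 2 `O=C(CCc1cccc2c1B(O)OC2)Nc1cccc(-c2cccc(F)c2)c1` gives 37000 nM as the higher of the two numbers so far. Among the compounds with values here, the only measured step is a 3.1-fold higher number from compound 1 to compound 2 (0.49 log units; beyond the scatter) for fluoro in place of hydrogen on an aromatic carbon. It is modest and lies beyond the scatter. Compound 3 `COc1cc(OC)cc(-c2cccc(NC(=O)CCc3cccc4c3B(O)OC4)c2)c1` carries 3,5-dimethoxyphenyl in place of 3-fluorophenyl on an aromatic carbon. Within the data shown here, the fluoro step bears on this only in part: compound 3 also lacks the fluoro, yet no measured compound carries 3,5-dimethoxyphenyl. Going by the modest size of a 3.1-fold higher number from compound 1 to compound 2 (0.49 log units; beyond the scatter) in reverse, a modest move to a lower number is expected in this assay and nothing larger. The expected step is a 2.3-fold lower number from compound 2 to compound 3 (0.36 log units; beyond the scatter) on this reasoning. For compound 3 the estimate is 16000 nM with an expected range from 6000 nM to 45000 nM as the upper end.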

Compound 3, half-maximal inhibitory concentration: 1700 nM
Beside the measured number, compound 3's estimate is 9.4-fold (0.97 log units) above it; measured number outside the range, below it.
By their numbers in this assay, from the lowest: compound 3; then compound 1; then compound 2.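

In this assay the swap to 3,5-dimethoxyphenyl gives a 22-fold lower number from compound 2 to compound 3 (1.34 log units; beyond the scatter) and, set against plain phenyl, a 7.1-fold lower number from compound 1 to compound 3 (0.85 log units; beyond the scatter) as well, which makes compound 3 the most potent of the three in this cell assay. Until now this place on the shared core had shown only a modest move to a higher number with fluoro, whereas this change shows that a substituent here can also push the number down, and by a large step. No measurement on hand accounts for the size or direction of this shift. The compounds shown cannot tell whether a single methoxy group would give part of the step or whether both are needed. On these data alone, whether a hydroxyl group, an amine or a carboxylic acid in the same place would move the number the same way also remains open.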